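The source may report more compounds than this note shows. Statements on the series, on what has been measured and on what is new or still open speak of the compounds shown alone.

Compound 3, `Cc1cc(-n2ccc3cccnc32)c2ncc(CSCCc3ccccc3)n2c1`, sits at the upper edge of what has been measured in an ADME assay on HEL cells (Homo sapiens) for cytotoxicity, with a stated time of 3 days (a lower number here means that less compound is tolerated, a higher number that more compound is tolerated), where compound 3 gives 100 ug/mL. Compound 2, `Cc1cc(-n2cccc2)c2ncc(CSCCc3ccccc3)n2c1`, gives 100 ug/mL in this assay, and the step of no change at the digits printed from compound 2 to compound 3 (within the scatter) shows that the two stand together. Compound 1, `Cc1cc(N2CCCC2)c2ncc(CSCCc3ccccc3)n2c1`, returns only a limit of the assay in this assay, > 100 ug/mL; the limit of > 100 ug/mL in this assay, at which 1 of the 3 values shown sits, is the one such limit among the three values. The steps of a number no higher from compound 1 to compound 2 (the limit leaves the size open) and a number no higher from compound 1 to compound 3 (the limit leaves the size open) therefore leave their size open.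

Compound 4, `Cc1cc(C#N)c2ncc(CSCCc3ccccc3)n2c1`, differs from compound 3 at one place: a group of 2 heavy atoms (1 carbon, 1 nitrogen; no ring) in place of a group of 9 heavy atoms (7 carbon, 2 nitrogen; one five-membered aromatic ring with 1 hetero atom, one six-membered aromatic ring with 1 hetero atom), on an aromatic carbon. For the measured compounds named here, no measured step swaps the group at this position for a cyano, so none bears directly on the change. The three measured compounds vary only at this same position, and across a pyrrolidin-1-yl, a 1H-pyrrol-1-yl and the larger fused bicyclic group the read-out stays at or beyond the same level. Compound 4 is therefore expected to show no step beyond the scatter, with no change at the digits printed from compound 3 to compound 4 (within the scatter) as the anticipated step. Compound 4 is estimated at 100 ug/mL in this assay, with a plausible range from 50 ug/mL to 200 ug/mL.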

Compound 4, minimum cytotoxic concentration: >= 20 ug/mL
Compound 4 gave a limit, no number; the forecaster's own chance of this, stated with the estimate: 45%; the middle value lies beyond the limit too.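

In this assay compound 4 returns >= 20 ug/mL, which is a limit of the assay and not a number. Its steps from compound 1, compound 2 and compound 3 therefore cannot be read. The compounds shown leave open whether cyano on this aromatic carbon changes the tolerated concentration at all, and where compound 4 truly stands among them.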